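The source may report more compounds than this note shows. Statements on the series, on what has been measured and on what is new or still open speak of the compounds shown alone.

Compound 1 `Clc1nc(Nc2ccccc2)nc(Nc2ccc(-c3nc4ccccc4o3)cc2)n1` gives 32600 nM in a functional assay on HT-29 cells (Homo sapiens) for cytotoxicity, read by MTT assay, with a stated time of 24 h; on this read-out higher numbers stand for weaker inhibition and lower numbers for stronger inhibition.
Compound 2 `COc1ccc(Nc2nc(Cl)nc(Nc3ccc(-c4nc5ccccc5o4)cc3)n2)cc1` gives 139000 nM in this assay.
Compound 3 `Fc1ccc(Nc2nc(Cl)nc(Nc3ccc(-c4nc5ccccc5o4)cc3)n2)cc1` gives 47000 nM in this assay.

Compound 3 stands second highest of the three numbers. Its nearest neighbour is compound 1: the step of a 1.4-fold higher number from compound 1 to compound 3 (0.16 log units; within the scatter) lies within the scatter, so the two cannot be ordered. Its furthest neighbour is compound 2: the step of a 3.0-fold lower number from compound 2 to compound 3 (0.47 log units; beyond the scatter) is beyond the scatter, as is the step of a 4.3-fold higher number from compound 1 to compound 2 (0.63 log units; beyond the scatter). All three measured steps exchange one group on the same aromatic ring for another, hydrogen, methoxy or fluoro, and at most they are modest.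

Compound 4 `Clc1nc(NCc2ccccc2)nc(Nc2ccc(-c3nc4ccccc4o3)cc2)n1` differs from compound 3 in benzyl in place of 4-fluorophenyl on a nitrogen on an aromatic ring. Among the measured compounds shown here, no measured step covers an exchange of this kind; the three known steps only show how far this series has moved so far, and none of them points a direction for it. The expected step of a 1.0-fold lower number from compound 3 to compound 4 (0.02 log units; within the scatter) is therefore set at no change beyond the scatter, with a wide range on both sides. Compound 4 is estimated at 45000 nM in this assay, between 12000 nM and 160000 nM.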

Compound 4, half-maximal inhibitory concentration: 44000 nM
For compound 4 the middle estimate is 1.0-fold (0.01 log units) above the measured one, within the range that was stated.
By their numbers in this assay, from the lowest: compounds 1, 4 and 3 (each within the scatter of the next); then compound 2.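

In this assay, among the compounds shown here, benzyl is the first group on this nitrogen that is neither phenyl nor a substituted phenyl, yet it cannot be told apart from two of the earlier groups: its exchange for 4-fluorophenyl gives a 1.1-fold lower number from compound 3 to compound 4 (0.03 log units; within the scatter), and its exchange for phenyl gives a 1.3-fold higher number from compound 1 to compound 4 (0.13 log units; within the scatter). Only 4-methoxyphenyl stands apart, with a 3.2-fold lower number from compound 2 to compound 4 (0.50 log units; beyond the scatter), so among the compounds shown, three different groups at this place give numbers within the scatter of the next, and compound 2 is the one exception. No evidence is available that bears on these results.

The compounds shown leave open whether a longer chain such as phenethyl, or a saturated amine such as morpholine in place of the whole arylamino group, would move the number beyond the scatter in either direction. They also leave open whether a change elsewhere on the shared core, such as an amine in place of the chlorine that all four compounds carry, would matter more than any exchange at this nitrogen.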